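A few compounds are considered here, and "the series" means these few. Any claim that something is new, unique, unknown or untested is made for them only; others in the source may bear on it.

Measured so far:
- compound 1 `O=C(O)COc1ccc(NCc2cccc(-c3ccccc3Cl)c2)cc1F` — 19.3 nM
- compound 2 `Cc1ccccc1-c1cccc(CNc2ccc(OCC(=O)O)c(F)c2)c1` — 4.8 nM

In a functional assay on CHO cells for agonist activity at Free fatty acid receptor 1 (Homo sapiens), read by FLIPR and calcium flux (a lower number here means that less compound is needed, a higher number that more compound is needed for the effect), compound 2 gives 4.8 nM, the lowest of the two numbers. Its nearest neighbour is compound 1, which gives 19.3 nM. Among the measured compounds shown here, the single measured step, a 4.0-fold lower number from compound 1 to compound 2 (0.60 log units; beyond the scatter), came from putting methyl in place of chloro on an aromatic carbon, and it lay beyond the scatter.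

Compound 3 `CC(C)c1ccccc1-c1cccc(CNc2ccc(OCC(=O)O)c(F)c2)c1` differs from compound 2 by isopropyl in place of methyl on an aromatic carbon — isopropyl in place of methyl on an aromatic carbon of a six-membered aromatic ring of carbon only, ortho to a large group. For the measured compounds named here, no measured step swaps methyl for isopropyl; the one step known touches the same position but exchanges chloro for methyl, so it bears on compound 3 only loosely. A modest change, if any, is expected, and the estimated step is a 1.7-fold higher number from compound 2 to compound 3 (0.22 log units; within the scatter). Compound 3 is therefore expected to give about 8 nM, within a range from 2.5 nM to 25 nM.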

Compound 3, half-maximal effective concentration: 86.2 nM
Compound 3: middle estimate off by 11-fold (1.03 log units), on the low side; measured number outside the range, above it.
By their numbers in this assay, from the lowest: compound 2; then compound 1; then compound 3.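

Swapping methyl for isopropyl in this assay gives an 18-fold higher number from compound 2 to compound 3 (1.25 log units; beyond the scatter), so the number at this aromatic carbon depends on the group it carries far more strongly than the one earlier step, from chloro to methyl, could show. Isopropyl also compares poorly with chloro, with a 4.5-fold higher number from compound 1 to compound 3 (0.65 log units; beyond the scatter), which leaves compound 3 with the highest number of the three, and its steps to both others lie beyond the scatter. Nothing available explains why the number rises with isopropyl.

Going by these compounds, whether ethyl at this carbon would give a number closer to that of compound 2 or of compound 3 remains open, so where the rise sets in is unknown. On these data alone, how methoxy or trifluoromethyl would behave at the same place is also open.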